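Chloro on the core of compound 1

A few compounds are considered here, and "the series" means these few. Any claim that something is new, unique, unknown or untested is made for them only; others in the source may bear on it.

In an ADME assay on CRFK cells (Felis catus) for cytotoxicity (a lower number here means that less compound is tolerated, a higher number that more compound is tolerated), compound 1 (`CCN(CC)CN1C(=O)/C(=N/NC(=S)Nc2ccc(Cl)cc2)c2ccccc21`) gives 4000 nM and holds the lowest number of the three measured compounds. Compound 3 (`CCN(CC)CN1C(=O)/C(=N/NC(=S)Nc2ccc(C)cc2)c2cc(Cl)ccc21`) gives 17500 nM and sits closest to it. Compound 2 (`CCN(CC)CN1C(=O)/C(=N/NC(=S)Nc2ccccc2)c2ccccc21`) gives 32300 nM and sits furthest away.

The next compound is compound 4 (`CCN(CC)CN1C(=O)/C(=N/NC(=S)Nc2ccc(Cl)cc2)c2cc(Cl)ccc21`). Its difference from compound 1 is chloro in place of hydrogen on an aromatic carbon and amounts to chloro in place of hydrogen on an aromatic carbon, on a six-membered aromatic ring of carbon only that is part of a fused or bridged system of two rings.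

Going by the values given here, only one measured step bears on this directly, and it runs the opposite way at a different place in the molecule: an 8.1-fold higher number from compound 1 to compound 2 (0.91 log units; beyond the scatter) when chloro gives way to hydrogen. Among the compounds with values here, compound 3 carries chloro at the same place as compound 4, but no measured step isolates that change, so the transfer is uncertain. The direction is therefore taken from compound 1 and compound 2, with a smaller size than that single step.

The expected change, a 2.2-fold lower number from compound 1 to compound 4 (0.35 log units; beyond the scatter) as estimated here, is a small move to a lower number, only just beyond the scatter. For compound 4 the estimated value is 1800 nM with an expected range from 600 nM to 6000 nM in this assay.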

Compound 4, half-maximal cytotoxic concentration: 9100 nM
Beside the measured number, compound 4's estimate is 5.1-fold (0.70 log units) below it; the measured number lies above the stated range.
By their numbers in this assay, from the lowest: compound 1; then compounds 4, 3 and 2 (each within the scatter of the next, the first and the last beyond it).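

Going by these compounds alone, at this position on the core, chloro in place of hydrogen gives a modest rise in this assay, with a 2.3-fold higher number from compound 1 to compound 4 (0.36 log units; beyond the scatter) as the first measured step at this place. The earlier step, an 8.1-fold higher number from compound 1 to compound 2 (0.91 log units; beyond the scatter), removes a chloro at a different place, so from compound 1 both losing that chloro and gaining one at this position give a higher number, and the effect of chloro at one place does not carry over to the other. With chloro held at this position, a 1.9-fold lower number from compound 3 to compound 4 (0.28 log units; within the scatter), so the chloro-for-methyl change elsewhere in the molecule cannot be resolved in this background. Nothing on hand explains the direction of the step at this position.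

Going by these compounds, this position rests on one matched pair, with chloro present at the other place, so the size of the change with hydrogen or methyl there remains open. Also open, on these data alone, is how fluoro, methoxy, an amine or a carboxylic acid at this position would compare with chloro and hydrogen.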